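Sulfanyl for methylamino on the core of compound 1

This account rests on a few compounds, and the source may have more. Where it says the series, first, only, none or still open, it means among the compounds named here.

Measured compounds:
- compound 1, `CNc1[nH]ccc2ncnc1-2`: < 5% in this assay, a limit of the assay
- compound 2, `CC1OC(n2cnc3c(N)nccc32)CC1O`: 25%
- compound 3, `OC[C@H]1O[C@@H](n2cnc3cnccc32)[C@H](O)[C@@H]1O`: < 5%; < 5% (2 entries), both entries a limit of the assay

All three have been run in a functional assay on EL4 cells (Mus musculus) for inhibition, tested at 100 uM; on this read-out lower numbers stand for less inhibition and higher numbers for more inhibition at the one concentration tested (going by the name of the read-out). For compound 1 the read-out is only a limit of the assay, < 5%, and not a number. Compound 3 likewise gives only the limit < 5%; < 5% (2 entries) in both of its entries. Going by the values given here, compound 2 is the one compound with a measured number, 25%. Compound 1 therefore stands at the floor of what this assay reports, with no number of its own; (the limit of < 5% in this assay, at which 1 of the 3 values shown sits).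

Compound 4, `Sc1[nH]ccc2ncnc1-2`, differs from compound 1 in one place: sulfanyl in place of methylamino on an aromatic carbon. Among the compounds with values here, no two measured compounds differ in a single place, so the size of this kind of step has not been measured.

Because compound 1 sits at the limit < 5%, the step from compound 1 to compound 4 is expected to be none beyond the scatter, with a low read-out again likely: a number at least 1 percentage points higher from compound 1 to compound 4 (that floor lies within the scatter). Compound 4 is estimated at 6%, with a range from 0% to 22%. The measurement of compound 4 is still to come.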

Compound 4, a percentage reported as inhibition, at one concentration (the size of the read-out at that concentration, not a potency): < 5%
Compound 4: a limit, no number (the forecaster's own chance of this, stated with the estimate: 55%); middle value at least 1 percentage points from the limit.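

In this assay compound 4 gives < 5%, a limit of the assay. Compound 1 also sits at a limit, so no step can be read between compound 1 and compound 4: the limit of < 5% in this assay, at which 2 of the 4 values shown sit.

The compounds shown leave open whether sulfanyl in place of methylamino on an aromatic carbon changes the read-out at all.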